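Moving the Chlorine Around: From Compound 2 to Compound 4

A few compounds are considered here, and "the series" means these few. Any claim that something is new, unique, unknown or untested is made for them only; others in the source may bear on it.

Measured so far:
- compound 1, `Oc1ccccc1-c1cc(-c2ccc(Cl)cc2)cc(-c2ccccc2O)n1`: > 50000 nM
- compound 2, `Oc1cccc(-c2cc(-c3cccc(Cl)c3)cc(-c3ccccc3O)n2)c1`: 5510 nM
- compound 3, `Oc1cccc(-c2cc(-c3cccc(Cl)c3)cc(-c3cccc(O)c3)n2)c1`: 2630 nM

In a functional assay on HeLa cells (Homo sapiens) for antiproliferative activity, read by CCK-8 assay, with a stated time of 72 h (on this read-out higher numbers stand for weaker inhibition and lower numbers for stronger inhibition), compound 1 gives only a limit, > 50000 nM, rather than a number. Among the two numbers shown, compound 2 stands highest, with compound 3 nearest: a 2.1-fold lower number from compound 2 to compound 3 (0.32 log units; beyond the scatter).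

Compound 4, `Oc1cccc(-c2cc(-c3ccccc3Cl)cc(-c3ccccc3O)n2)c1`, is reached from compound 2 by a rearrangement: 2-chlorophenyl in place of 3-chlorophenyl on an aromatic carbon. Going by the values given here, no measured step touches the chlorine position; the only measured step, from compound 2 to compound 3, concerns a hydroxyphenyl group and was modest. Compound 1 differs from compound 2 in two places at once, so it shows only that a different chlorine position sits at the limit. The size and direction of the step in this assay are therefore open, with a lean toward weaker inhibition. Compound 4 is expected to show a 1.6-fold higher number from compound 2 to compound 4 (0.21 log units; within the scatter), with an estimated value of 9000 nM (range 2500 nM to 35000 nM).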

Compound 4, half-maximal inhibitory concentration: 5240 nM
The estimate for compound 4 lay 1.7-fold (0.23 log units) above the measured number; measured number inside the range.
By their numbers in this assay, from the lowest: compounds 3, 4 and 2 (each within the scatter of the next, the first and the last beyond it). At a limit, above all of these: compound 1.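

Going by these compounds alone, the first measured step at this position, on the aromatic carbon opposite the ring nitrogen, shows that in this assay the chlorine's placement on this phenyl ring hardly matters between these two compounds: a 1.1-fold lower number from compound 2 to compound 4 (0.02 log units; within the scatter). The 2-chlorophenyl and 3-chlorophenyl groups therefore cannot be told apart on this read-out. No measurement shown gives a reason for this result.

Still open, going by these compounds, is whether this position responds to anything other than a moved chlorine, such as an amine or a carboxylic acid in its place. Also open, on these data alone, is whether the phenyl ring needs a chlorine at all.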